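Cyano for trifluoromethyl in a biaryl amine series

The compounds below may be only part of what the source reports. "The series", "measured", "known", "first", "only" and "open" are said of these compounds alone.

Measured so far in a functional assay on Jurkat cells (Homo sapiens) for activation, with a stated time of 24 h; on this read-out higher numbers stand for an effect only at larger amounts of compound and lower numbers for an effect already at smaller amounts:
compound 1 `Cc1ccc(-c2ccc(NCc3ccccc3O)cc2)cc1`: 3790 nM
compound 2 `Oc1ccccc1CNc1ccc(-c2ccc(-c3ccccc3)cc2)cc1`: "not active" (no number reported)
compound 3 `Oc1ccccc1CNc1ccc(-c2ccc(C(F)(F)F)cc2)cc1`: "not active" (no number reported)

The three compounds share the core of compound 1 and differ only in the group on the terminal ring. Among the compounds with values here, compound 1 is the sole member with a number; in this assay compound 1 gives 3790 nM. For compound 2 this assay reports "not active" (no number reported), with no number attached. Within the data shown here, compound 3 stands in the same position: this assay reports "not active" (no number reported) for compound 3, so no number exists for it, and no step toward it can be sized.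

Compound 4 `N#Cc1ccc(-c2ccc(NCc3ccccc3O)cc2)cc1` is the next entry. Relative to compound 3 the change is cyano in place of trifluoromethyl on an aromatic carbon. Among the measured compounds shown here, no measured step of this kind exists, so the size and direction of the step in this assay cannot be anchored; a weak number is as plausible as another entry without one. Compound 4 is expected to give about 6000 nM in this assay, with a range from 1500 nM to 25000 nM.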

Compound 4, half-maximal effective concentration: "not active" (no number reported)
For compound 4 the study gives words and no number, so the estimate cannot be set against anything.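

In this assay, within the data shown here, compound 3 and compound 4 both carry words rather than numbers, so no step between them can be read. No measured evidence bears on this result. The compounds shown leave open whether cyano and trifluoromethyl differ at all on this read-out.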